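Swapping a hydroxy-piperidine for an ethyl-piperazine on the core

A few compounds are considered here, and "the series" means these few. Any claim that something is new, unique, unknown or untested is made for them only; others in the source may bear on it.

Compound 1 `Cc1nc(N2CCN(C3CCOCC3)CC2)nc2ccc(NC(=O)COc3ccc(Cl)cc3)cc12`: 45 nM
Compound 2 `Cc1nc(N2CCN(S(C)(=O)=O)CC2)nc2ccc(NC(=O)COc3ccc(Cl)cc3)cc12`: > 10000 nM
Compound 3 `Cc1nc(N2CCC(C)(O)CC2)nc2ccc(NC(=O)COc3ccc(Cl)cc3)cc12`: 237 nM

In an assay on CHO-K1 cells for displacement of a labelled ligand from melanin-concentrating hormone receptor 1 (Homo sapiens), with a stated time of 2 h (on this read-out higher numbers stand for weaker inhibition and lower numbers for stronger inhibition), compound 1 gives 45 nM and compound 3 gives 237 nM, the higher of the two numbers. Compound 2 gives > 10000 nM, which is a limit of the assay and not a number (the limit of > 10000 nM in this assay, at which 1 of the 3 values shown sits). Compound 4 `CCN1CCN(c2nc(C)c3cc(NC(=O)COc4ccc(Cl)cc4)ccc3n2)CC1` differs from compound 3 in one place: 4-ethylpiperazin-1-yl in place of 4-hydroxy-4-methylpiperidin-1-yl on an aromatic carbon. Within the data shown here, two measured steps touch this region of the core, and both were large: an at least 220-fold higher number from compound 1 to compound 2 (2.34 log units; beyond the scatter) and an at least 42-fold lower number from compound 2 to compound 3 (1.62 log units; beyond the scatter). Each of them, however, runs through the limit of compound 2, so neither tells directly how a piperazine carrying an alkyl group compares with the hydroxy-piperidine of compound 3. The closest guide is compound 1, which also carries a piperazine on the same aromatic carbon and gives 45 nM. Compound 4 is therefore expected to sit near that, a step of a 4.7-fold lower number from compound 3 to compound 4 (0.68 log units; beyond the scatter), and its estimated value is 50 nM with a range of 10 nM to 250 nM.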

Compound 4, half-maximal inhibitory concentration: 690 nM
For compound 4 the middle estimate is 14-fold (1.14 log units) below the measured one, and the stated range ends below it.
By their numbers in this assay, from the lowest: compound 1; then compound 3; then compound 4. At a limit, above all of these: compound 2.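

In this assay, the step of a 2.9-fold higher number from compound 3 to compound 4 (0.46 log units; beyond the scatter) shows that a piperazine at this aromatic carbon does not by itself give a lower number than the 4-hydroxy-4-methylpiperidin-1-yl group. The group on the piperazine's outer nitrogen matters greatly: with ethyl in place of oxan-4-yl the result is a 15-fold higher number from compound 1 to compound 4 (1.19 log units; beyond the scatter), and with ethyl in place of methylsulfonyl it is an at least 14-fold lower number from compound 2 to compound 4 (1.16 log units; beyond the scatter), which places ethyl between the other two groups. The value of compound 2 is a limit and not a number: the limit of > 10000 nM in this assay, at which 1 of the 4 values shown sits.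

The compounds shown leave open how a piperazine with only a hydrogen on that nitrogen, or with a methyl group or a longer chain such as propyl, would compare with ethyl. They also leave open whether a smaller ring on that nitrogen, such as oxetane, would match oxan-4-yl.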